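The source may report more compounds than this note shows. Statements on the series, on what has been measured and on what is new or still open speak of the compounds shown alone.

Measured compounds:
- compound 1 `c1ccc(-c2cc(-c3ccsc3)cc(-c3ccccn3)n2)nc1` gives 0.0017 ug/mL in a functional assay on PC-3 cells (Homo sapiens) for antiproliferative activity; a higher number here means a weaker inhibitor of growth, a lower number a stronger inhibitor of growth
- compound 2 `c1ccc(-c2cc(-c3ccccn3)nc(-c3ccccn3)c2)cc1` gives 0.017 ug/mL in this assay
- compound 3 `c1ccc(-c2cc(-c3ccsc3)cc(-c3cccnc3)n2)nc1` gives 0.054 ug/mL in this assay

Compound 3 has the highest number of the three in this assay, so it is the weakest inhibitor of growth among them. Its nearest neighbour is compound 2, and the two measured steps are a 10-fold higher number from compound 1 to compound 2 (1.00 log units; beyond the scatter) and a 32-fold higher number from compound 1 to compound 3 (1.50 log units; beyond the scatter).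

Compound 4 `c1ccc(-c2cc(-c3cccs3)cc(-c3cccnc3)n2)nc1` keeps everything in compound 3 except for a single change: thiophen-2-yl in place of thiophen-3-yl on an aromatic carbon. The two compounds hold the same atoms, joined differently.

For the measured compounds named here, none of the measured steps tests this particular swap. The closest guide is the step from compound 1 to compound 2, where the thiophen-3-yl group was exchanged for phenyl and the number moved by a 10-fold higher number from compound 1 to compound 2 (1.00 log units; beyond the scatter); this shows that the group at this place can matter, but gives no direction for moving the point of attachment within the same ring. The step of a 32-fold higher number from compound 1 to compound 3 (1.50 log units; beyond the scatter) concerns a different group and does not bear on it.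

With no direct guide, the expectation for compound 4 in this assay is a step of no change at the digits printed from compound 3 to compound 4 (within the scatter), that is, no change beyond the scatter. Compound 4 is therefore estimated at 0.054 ug/mL, with a range from 0.015 ug/mL to 0.2 ug/mL.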

Compound 4, concentration for 50% growth inhibition: 0.031 ug/mL
Beside the measured number, compound 4's estimate is 1.7-fold (0.24 log units) above it; measured number inside the range.
By their numbers in this assay, from the lowest: compound 1; then compounds 2, 4 and 3 (each within the scatter of the next, the first and the last beyond it).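

In this assay, moving the point of attachment within the thiophene ring, with thiophen-2-yl in place of thiophen-3-yl, gives a 1.7-fold lower number from compound 3 to compound 4 (0.24 log units; within the scatter) and so does not separate the two thiophene forms at this place on the shared core. The earlier exchange of thiophen-3-yl for phenyl gave a 10-fold higher number from compound 1 to compound 2 (1.00 log units; beyond the scatter) and showed that the group here can matter, whereas this pair shows that, with a pyridin-3-yl group elsewhere on the core, the two points of attachment give values within the usual scatter. Nothing shown here offers a measured explanation for how closely these two compounds agree.

The compounds shown leave open whether thiophen-2-yl and thiophen-3-yl would also stay this close in the setting of compound 1, which carries a pyridin-2-yl group in place of the pyridin-3-yl group and has the lowest number of the set. Going by these compounds, it also remains open how growth inhibition would respond if this place carried a non-aromatic group, such as a simple amine or a longer alkyl chain, instead of an aromatic ring.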